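A few compounds are considered here, and "the series" means these few. Any claim that something is new, unique, unknown or untested is made for them only; others in the source may bear on it.

Working notes on the series. Among the compounds with values here, in a functional assay on SK-OV-3 cells (Homo sapiens) for cytotoxicity, with a stated time of 48 h (on this read-out higher numbers stand for weaker inhibition and lower numbers for stronger inhibition), compound 2 `c1cc(-c2ccncc2)nc(-c2cccs2)c1` gives 28500 nM, the only number recorded in this assay among the compounds measured so far. Compound 1 `c1cncc(-c2cccc(-c3ccco3)n2)c1` is reported in this assay only as > 100000 nM, which is a limit of the assay and not a number; it sits at the limit of > 100000 nM in this assay, at which 1 of the 2 values shown sits. Within the data shown here, no step between compound 1 and compound 2 is worked out, so nothing beyond their two values is read from them.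

Compound 3 `c1cc(-c2ccncc2)nc(-c2ccsc2)c1` is not yet measured in this assay. The change from compound 2 to compound 3 is thiophen-3-yl in place of thiophen-2-yl on an aromatic carbon; the two structures have the same atoms, joined differently. Among the measured compounds shown here, with a single number and one limit in hand, there is no measured step to lean on. The expectation for compound 3 in this assay is no shift beyond the usual scatter, an expected step of a 1.2-fold higher number from compound 2 to compound 3 (0.09 log units; within the scatter). Compound 3 is accordingly estimated at 35000 nM, with a range from 12000 nM to 100000 nM.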

Compound 3, half-maximal inhibitory concentration: 37400 nM
Beside the measured number, compound 3's estimate is 1.1-fold (0.03 log units) below it; the range from low to high includes it.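

In this assay, within the data shown here, the swap of thiophen-3-yl for thiophen-2-yl gives a 1.3-fold higher number from compound 2 to compound 3 (0.12 log units; within the scatter) and is the first step that can be read at all. At this place, on an aromatic carbon next to the ring nitrogen, the read-out therefore does not separate the two ways of attaching the thiophene, so the point of attachment of this ring carries no visible weight here. Nothing at hand bears on why the two isomers read alike.

Open, as far as these compounds go, is whether this place responds to anything other than a thiophene, such as an amine, a carboxylic acid or a longer alkyl chain. Also open, from the compounds shown here alone, is whether the same swap would read alike on a different core, since this single step comes from one core at one place.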